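From Methyl to Fluoro: Estimating Compound 4

The compounds below may be only part of what the source reports. "The series", "measured", "known", "first", "only" and "open" are said of these compounds alone.

Of the compounds shown here, three sharing one core have been tested in a functional assay on HCT-116 cells (Homo sapiens) for cytotoxicity, read by MTT assay, with a stated time of 72 h; a lower number here means a stronger inhibitor, a higher number a weaker inhibitor. Compound 1 `Cc1ccc(S(=O)(=O)c2nc3ccccc3nc2Nc2ccc(N)cc2)cc1` gives 11500 nM, compound 2 `Cc1ccc(S(=O)(=O)c2nc3ccccc3nc2Nc2cccc(N)c2)cc1` gives 2390 nM, and compound 3 `Cc1ccc(S(=O)(=O)c2nc3ccccc3nc2Nc2ccc(C(F)(F)F)cc2)cc1` gives 950 nM. Compound 2 therefore holds the middle place among the three numbers.

Compound 4 `Nc1cccc(Nc2nc3ccccc3nc2S(=O)(=O)c2ccc(F)cc2)c1` differs from compound 2 by one small change: fluoro in place of methyl on an aromatic carbon. In words, this is fluoro in place of methyl on an aromatic carbon, so that 4-methylphenyl becomes 4-fluorophenyl.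

The measured steps all concern the group on the nitrogen, not this one. Moving the amino group gave a 4.8-fold lower number from compound 1 to compound 2 (0.68 log units; beyond the scatter), a modest step. Trifluoromethyl in place of amino gave a 12-fold lower number from compound 1 to compound 3 (1.08 log units; beyond the scatter), a large one. The remaining comparison gave a 2.5-fold lower number from compound 2 to compound 3 (0.40 log units; beyond the scatter), again modest. Among the compounds with values here, no measured step tests the 4-methylphenyl group, so the starting point stays compound 2 at 2390 nM. The large step still shows that a change elsewhere on the core can move the number considerably, so the range should stay wide.

The expected step in this assay is a 1.1-fold lower number from compound 2 to compound 4 (0.04 log units; within the scatter), and it is not expected to exceed the scatter. For compound 4 the estimated value is 2200 nM, with an expected range from 900 nM to 6000 nM.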

Compound 4, half-maximal inhibitory concentration: 6790 nM
For compound 4 the middle estimate is 3.1-fold (0.49 log units) below the measured one; measured number above the stated range.
By their numbers in this assay, from the lowest: compound 3; then compound 2; then compounds 4 and 1 (each within the scatter of the next).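

Until now, every measured step concerned the group on the nitrogen, so the 4-methylphenyl group had not been tested. In this assay, fluoro in place of methyl gives a 2.8-fold higher number from compound 2 to compound 4 (0.45 log units; beyond the scatter), which shows that this position on the far side of the shared core does affect the result, and that, in this pair, the compound with methyl is the stronger inhibitor. The swap exchanges only 1 heavy atom for 1 heavy atom, with no change in the counts of hydrogen-bond donors, hydrogen-bond acceptors, rings or net charge, yet the step lies beyond the usual scatter, and nothing available explains why this small change has that effect.

On these data alone, this position is tested by a single pair, both members carrying the 3-aminophenyl group on the nitrogen, so it remains open whether the same swap would give a similar step alongside the 4-(trifluoromethyl)phenyl group of compound 3. Also open, as far as these compounds go, is how a chloro group, a methoxy group or a plain hydrogen on this aromatic carbon would compare with methyl and fluoro.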